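This account rests on a few compounds, and the source may have more. Where it says the series, first, only, none or still open, it means among the compounds named here.

Working notes on the series in a functional assay on NCI-H460 cells (Homo sapiens) for antiproliferative activity, read by CCK-8 assay, with a stated time of 72 h, tested at 2 uM; a lower number here means a weaker effect, a higher number a stronger effect of the compound at the concentration tested. Three compounds have been run. Compound 1 `Nc1ccccc1NC(=O)/C=C/c1ccc(Cn2cnc3c(Nc4cccc(Cl)c4)nc(Cl)nc32)cc1` gives 7.11%. Compound 2 `CCCCn1cnc2c(NCc3ccc(C(=O)Nc4ccccc4N)cc3)nc(Cl)nc21` gives 19.7%. Compound 3 `CCCCn1cnc2c(Nc3ccccc3)nc(NCOCc3ccc(C(=O)Nc4ccccc4N)cc3)nc21` gives 27.7%. On these numbers compound 2 stands second highest of the three. Its nearest neighbour is compound 3, whose number sits higher by an amount within the scatter, so the two cannot be ordered. Compound 1 is the furthest off, lower by an amount beyond the scatter. No two of the measured compounds differ in one place only, so no single step can be read from them.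

The next compound, compound 4 `Nc1ccccc1NC(=O)c1ccc(CNc2nc(Cl)nc3c2ncn3Cc2ccccc2)cc1`, is to be measured in this assay. It differs from compound 2 in one place:

phenyl in place of propyl on a saturated chain carbon bound to an aromatic nitrogen

Within the data shown here, nothing measured so far isolates this change, so the step is expected to be small, no larger than the scatter, with no direction that the data support. The expected step of a number 1.3 percentage points higher from compound 2 to compound 4 (within the scatter) is therefore set close to zero. On that basis compound 4 is estimated at 21% in this assay, with the likely range running from 7% to 38%.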

Compound 4, a percentage reported as inhibition, at one concentration (the size of the read-out at that concentration, not a potency): 43.8%
Estimate against measurement, compound 4: 22.8 percentage points below, and the stated range ends below it.
By their numbers in this assay, from the lowest: compound 1; then compounds 2 and 3 (each within the scatter of the next); then compound 4.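

In this assay, among these compounds, phenyl in place of propyl on a saturated chain carbon bound to an aromatic nitrogen gives a number 24.1 percentage points higher from compound 2 to compound 4 (beyond the scatter), the first step that can be read, and it shows that the group at this place can shift the read-out. Read one bond further out as butyl to benzyl, the change brings in one six-membered aromatic ring of carbon only and leaves the hydrogen-bond donor and acceptor counts of the exchanged groups at 0, so the step goes with a change in the carbon group alone for this pair. Nothing at hand explains the size of this step.

This one pair cannot tell whether the step follows the aromatic ring or simply the larger group, a question that a cyclohexyl group or a longer chain at the same place would address. On these data alone, whether the same change gives a similar step with the other side chains also stays open, as does its effect beyond the single concentration tested.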